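The source may report more compounds than this note shows. Statements on the series, on what has been measured and on what is new or still open speak of the compounds shown alone.

Measured so far:
- compound 1, `O=S(=O)(NCCNc1nccc(-c2c(-c3cccc(F)c3)nc3sccn23)n1)c1ccc(Cl)cc1`: 18600 nM
- compound 2, `O=S(=O)(NCCNc1nccc(-c2c(-c3cccc(F)c3)nc3sccn23)n1)c1ccc(C(F)(F)F)cc1`: 7440 nM

In a functional assay on A-375 cells (Homo sapiens) for cytotoxicity, read by MTT assay (on this read-out lower numbers stand for stronger inhibition and higher numbers for weaker inhibition), compound 1 gives the highest of the two numbers; the nearest is compound 2, reached by a 2.5-fold lower number from compound 1 to compound 2 (0.40 log units; beyond the scatter). Compound 3, `O=S(=O)(NCCCNc1nccc(-c2c(-c3cccc(F)c3)nc3sccn23)n1)c1ccccc1`, is not yet measured. It differs from compound 1 by ((phenylsulfonyl)amino)methyl in place of ((4-chlorophenyl)sulfonyl)amino on a saturated chain carbon, two bonds along the chain from a nitrogen on an aromatic ring. Going by the values given here, the only measured step swaps one group on the aromatic ring for another, so it bears on compound 3 only loosely: removing the chloro and lengthening the chain has no direct counterpart. No step beyond the scatter is expected; compound 3 is estimated at 22000 nM (range 8000 nM to 60000 nM), meaning a 1.2-fold higher number from compound 1 to compound 3 (0.07 log units; within the scatter).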

Compound 3, half-maximal inhibitory concentration: 6600 nM
Estimate against measurement, compound 3: 3.3-fold (0.52 log units) above; the whole stated range lies above it.
By their numbers in this assay, from the lowest: compounds 3 and 2 (each within the scatter of the next); then compound 1.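

Swapping ((4-chlorophenyl)sulfonyl)amino for ((phenylsulfonyl)amino)methyl on the saturated chain carbon gives, in this assay, a 2.8-fold lower number from compound 1 to compound 3 (0.45 log units; beyond the scatter). The earlier step changed only a group on an aromatic ring, whereas this one shows that a change at the chain can also move the number beyond the scatter, here towards stronger inhibition. No available evidence explains this shift.

As far as these compounds go, the step both removes the chloro and adds a chain carbon, so the share of each remains unknown. From the compounds shown here alone, whether a longer chain would lower the number further also remains open.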